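Ester side chain on the sulfur: notes toward compound 3

The source may report more compounds than this note shows. Statements on the series, on what has been measured and on what is new or still open speak of the compounds shown alone.

Measured so far:
compound 1, `CCCc1nc(C)c2cnnc(SCC(=O)OCC)n12`, in a functional assay for inhibition, with Homo sapiens as the target (on this read-out higher numbers stand for weaker inhibition and lower numbers for stronger inhibition), gives > 48000 nM
compound 2, `Cc1nc(C)n2c(S)nncc12`, in this assay gives > 48000 nM

Both numbers are limits of the assay, not measured values. Compound 2 stands at the limit > 48000 nM, so on the numbers shown compound 2 sits on the floor of this assay, where (the limit of > 48000 nM in this assay, at which 2 of the 2 values shown sit). Compound 3, `CCOC(=O)CSc1nncc2c(C)nc(C)n12`, differs from compound 2 by (ethoxycarbonyl)methyl in place of hydrogen on a sulfur. For the measured compounds named here, no step between measured compounds is available to size this change. Compound 1 carries the same (ethoxycarbonyl)methyl on its sulfur and in this assay also gives only the limit > 48000 nM, which offers no sign that this change brings inhibition into the measurable range. The expected step that the limit leaves unreadable from compound 2 to compound 3 is therefore none beyond the scatter, most probably another limit. Compound 3 is estimated at 60000 nM, within 20000 nM to 200000 nM.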

Compound 3, half-maximal inhibitory concentration: > 48000 nM
Compound 3 gave a limit, no number; the forecaster's own chance of this, stated with the estimate: 85%; the middle value lies beyond the limit too.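

Compound 3 gives only a limit, like compound 1 and compound 2, so no step among these three compounds can be read: the limit of > 48000 nM in this assay, at which 3 of the 3 values shown sit.

The compounds shown leave open whether any group on the sulfur brings inhibition into the measurable range.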